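Removing a Fluorine from a Urea: Permeability Expectation

A few compounds are considered here, and "the series" means these few. Any claim that something is new, unique, unknown or untested is made for them only; others in the source may bear on it.

Compound 1, `CSc1ccc(NC(=O)Nc2cc(C)nc3ccccc23)cc1`, gives 473 10^-6 cm/s.
Compound 2, `COc1ccc(NC(=O)Nc2cc(C)nc3ccccc23)cc1F`, gives 50 10^-6 cm/s.

Both compounds were tested in an ADME assay for permeability, using PAMPA, at pH 7.4; on this read-out higher numbers stand for higher permeability and lower numbers for lower permeability. Among the measured compounds shown here, compound 2 stands at the lowest of the two numbers; its only neighbour is compound 1, whose number is higher by a step beyond the usual scatter. Compound 3, `COc1ccc(NC(=O)Nc2cc(C)nc3ccccc23)cc1`, has not yet been measured. It differs from compound 2 in one place: hydrogen in place of fluoro on an aromatic carbon. For the measured compounds named here, no measured pair shows this exact change, so the values of compound 1 and compound 2 give only a rough frame for what to expect. In this assay a small rise is expected, at the edge of the usual scatter, so a result near compound 2 would not be surprising: the expected step is a 2.0-fold higher number from compound 2 to compound 3 (0.30 log units; within the scatter). Compound 3 is thus expected to give 100 10^-6 cm/s, with a likely range from 30 10^-6 cm/s to 300 10^-6 cm/s.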

Compound 3, apparent permeability: 787 10^-6 cm/s
For compound 3 the middle estimate is 7.9-fold (0.90 log units) below the measured one; measured number above the stated range.
By their numbers in this assay, from the lowest: compound 2; then compounds 1 and 3 (each within the scatter of the next).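

In this assay, this single aromatic position carries a large step: hydrogen in place of fluoro, ortho to a methoxy group, gives a 16-fold higher number from compound 2 to compound 3 (1.20 log units; beyond the scatter). Losing just one heavy atom can thus move this read-out well beyond the scatter. Compound 3 keeps the methoxy group of compound 2. It does not share the low number of compound 2. Methoxy in place of methylsulfanyl, by contrast, gives a 1.7-fold higher number from compound 1 to compound 3 (0.22 log units; within the scatter), which lies within the scatter, so with hydrogen at this position the two groups cannot be told apart.

Nothing available explains why this one fluorine is linked to so large a step. On these data alone, whether a chlorine or a methyl group at this position would track fluoro or hydrogen remains open, as does whether fluoro would give a similar step in compound 1.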